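This account rests on a few compounds, and the source may have more. Where it says the series, first, only, none or still open, it means among the compounds named here.

Compound 1 `O=C(COc1ccc(C(=O)/C=C/c2ccc(F)c(F)c2)cc1)N[C@H]1CCOC1=O` was tested in a functional assay on PC-3 cells (Homo sapiens) for antiproliferative activity, read by MTT assay, with a stated time of 72 h (on this read-out higher numbers stand for weaker inhibition and lower numbers for stronger inhibition), and gave 21900 nM. This is the only numeric result available, since the other compound reached only a limit, as shown by the limit of > 64000 nM in this assay, at which 1 of the 2 values shown sits. Compound 2 `O=C1OCC[C@@H]1NC(=S)SCCOc1ccccc1Cc1ccccc1` gave in this assay a limit of > 64000 nM, not a number. Compound 3 `O=C(COc1ccc(C(=O)/C=C/c2cccc([N+](=O)[O-])c2)cc1)N[C@H]1CCOC1=O` is not yet measured; it differs from compound 1 by 3-nitrophenyl in place of 3,4-difluorophenyl on a double-bonded chain carbon bound to a double-bonded chain carbon. Among the measured compounds shown here, with no measured step of this kind to lean on, the expected change in this assay is small and could fall within the usual scatter. Compound 3 is therefore expected to give 16000 nM, between 6000 nM and 45000 nM, a step of a 1.4-fold lower number from compound 1 to compound 3 (0.14 log units; within the scatter).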

Compound 3, half-maximal inhibitory concentration: 56300 nM
For compound 3 the middle estimate is 3.5-fold (0.55 log units) below the measured one; measured number outside the range, above it.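

In this assay, 3-nitrophenyl in place of 3,4-difluorophenyl gives a 2.6-fold higher number from compound 1 to compound 3 (0.41 log units; beyond the scatter). Among the compounds shown here, this is the first measured step at this position, and it shows that the group here can change the read-out, with weaker inhibition for the nitro-bearing compound. Nothing measured here explains the step. The compounds shown leave open whether removing the fluorines or adding the nitro group matters more. They also leave open how a plain phenyl or a 3-aminophenyl in the same place would compare.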